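Halogen swap on a benzyl arm of a nucleoside core

A few compounds are considered here, and "the series" means these few. Any claim that something is new, unique, unknown or untested is made for them only; others in the source may bear on it.

Compound 2 `OC[C@H]1O[C@@H](n2cnc3c(NCc4cccc(Br)c4)ncnc32)[C@H](O)[C@@H]1O` and compound 1 `OC[C@H]1O[C@@H](n2cnc3c(NCc4ccccc4F)ncnc32)[C@H](O)[C@@H]1O` share one core and differ only in the group carried on a saturated chain carbon bound to a nitrogen on an aromatic ring. In a functional assay on K562 cells (Homo sapiens) for antiproliferative activity, with a stated time of 72 h (a lower number here means a stronger inhibitor, a higher number a weaker inhibitor), compound 1 gives 33200 nM, while compound 2 gives 19700 nM, the lowest of the two numbers, though the gap between them stays within the scatter.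

Compound 3 `OC[C@H]1O[C@@H](n2cnc3c(NCc4ccc(Cl)cc4Cl)ncnc32)[C@H](O)[C@@H]1O` continues along the same arm: 2,4-dichlorophenyl in place of 3-bromophenyl on a saturated chain carbon bound to a nitrogen on an aromatic ring. Among the compounds with values here, the only measured step that bears on such a change is a 1.7-fold lower number from compound 1 to compound 2 (0.23 log units; within the scatter), where exchanging one halogenated phenyl group for another moved the number no further than repeat measurements do. The change to compound 3 is of the same kind, so no step beyond the scatter is expected in this assay, with a 1.1-fold lower number from compound 2 to compound 3 (0.04 log units; within the scatter) as the estimated step. Compound 3 is therefore expected to give about 18000 nM, likely between 6000 nM and 50000 nM.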

Compound 3, half-maximal inhibitory concentration: 106000 nM
The estimate for compound 3 lay 5.9-fold (0.77 log units) below the measured number; measured number above the stated range.
By their numbers in this assay, from the lowest: compounds 2 and 1 (each within the scatter of the next); then compound 3.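

At this place on the shared core, exchanging one halogenated phenyl group for another is not always neutral. In this assay, 2,4-dichlorophenyl gives a 5.4-fold higher number from compound 2 to compound 3 (0.73 log units; beyond the scatter) and a 3.2-fold higher number from compound 1 to compound 3 (0.50 log units; beyond the scatter), so compound 3 is the weakest inhibitor of the three, whereas the earlier swap between the other two groups stayed within the scatter. No measurement at hand explains why this group weakens the antiproliferative effect.

With only these three compounds, the loss cannot be assigned to the kind of halogen, the number of halogens or where they sit on the ring, since all of these differ at once in compound 3. From the compounds shown here alone, it also remains open how a plain phenyl group or a methoxyphenyl group, with no halogen at all, would compare at this place.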